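Heterocycle swap at the chain carbon: thiazolidinedione to hydantoin

The source may report more compounds than this note shows. Statements on the series, on what has been measured and on what is new or still open speak of the compounds shown alone.

Three compounds of the series carry a number in a functional assay on CHO cells for antagonist activity at prostaglandin E2 receptor EP3 subtype (Homo sapiens), read by cAMP accumulation, with a stated time of 30 min (on this read-out higher numbers stand for weaker inhibition and lower numbers for stronger inhibition), so far. Compound 1 `O=C1NC(=O)/C(=C/C(c2ccc(-c3ccc4cccc(F)c4c3)[nH]c2=O)C2CCCCC2)O1` gives 8 nM; compound 2 `CC(C)C(c1ccc(-c2ccc3cccc(F)c3c2)[nH]c1=O)C1SC(=O)NC1=O` gives 110 nM; compound 3 `CC(C)/C(=C1\NC(=O)OC1=O)c1ccc(-c2ccc3cccc(F)c3c2)[nH]c1=O` gives 680 nM. Among these, compound 2 stands second highest: its number lies above that of compound 1 and below that of compound 3, both gaps beyond the usual scatter of the read-out. Compound 4 `CC(C)C(c1ccc(-c2ccc3cccc(F)c3c2)[nH]c1=O)C1NC(=O)NC1=O` has not been measured in this assay.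

Compound 4 differs from compound 2 at one place: 2,5-dioxoimidazolidin-4-yl in place of 2,4-dioxo-1,3-thiazolidin-5-yl on a saturated chain carbon bound to an aromatic carbon and a saturated chain carbon. Among the compounds with values here, no step between two measured compounds shows this kind of exchange, so nothing so far sets its size.

Compound 4 is expected to come out with a higher number in this assay than compound 2, with the step of a 2.7-fold higher number from compound 2 to compound 4 (0.44 log units; beyond the scatter) estimated to be moderate and beyond the scatter, though the uncertainty is wide. The expected value for compound 4 is 300 nM, with a range from 100 nM to 1000 nM.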

Compound 4, half-maximal inhibitory concentration: 320 nM
Estimate against measurement, compound 4: 1.1-fold (0.03 log units) below, and the stated range covers the measured number.
By their numbers in this assay, from the lowest: compound 1; then compound 2; then compound 4; then compound 3.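

Within the data shown here, with the 2,5-dioxoimidazolidin-4-yl group in place of the 2,4-dioxo-1,3-thiazolidin-5-yl group on the saturated chain carbon, this assay gives a 2.9-fold higher number from compound 2 to compound 4 (0.46 log units; beyond the scatter), the first single-place exchange that can be read. At this position, the change of ring, which swaps sulfur for a second nitrogen and moves the count from 1 to 2 hydrogen-bond donors and from 3 to 2 acceptors, weakens inhibition modestly but does not abolish it. Nothing available accounts for the size of this step.

On these data alone, whether a carboxylic acid on the same saturated chain carbon would keep inhibition at a similar level remains open. As far as these compounds go, compound 1 and compound 3 differ from compound 2 and compound 4 in more than one place, so whether the step carries over to other chain groups also remains open.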